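Replacing the sulfamoylphenyl of compound 1 with a bicyclic ether

The source may report more compounds than this note shows. Statements on the series, on what has been measured and on what is new or still open speak of the compounds shown alone.

Measured so far:
compound 1, `Cc1cn([C@H]2C[C@@H](n3cc(COc4ccc(S(N)(=O)=O)cc4)nn3)[C@@H](CO)O2)c(=O)[nH]c1=O`, 59.1 nM
compound 2, `Cc1cn([C@H]2C[C@@H](n3cc(COC(=O)c4ccc(S(N)(=O)=O)cc4)nn3)[C@@H](CO)O2)c(=O)[nH]c1=O`, 4800 nM
compound 3, `Cc1cn([C@H]2C[C@@H](n3cc(CNC(=O)Nc4cccc(S(N)(=O)=O)c4)nn3)[C@@H](CO)O2)c(=O)[nH]c1=O`, 3240 nM

In an assay on isolated protein for inhibition of carbonic anhydrase 5A, mitochondrial (Homo sapiens), read by stopped-flow (a lower number here means a stronger inhibitor, a higher number a weaker inhibitor), compound 1 gives 59.1 nM, the lowest of the three numbers. Compound 3 stands at 3240 nM and compound 2 at 4800 nM, both gaps to compound 1 lying beyond the scatter. Compound 4 `Cc1cn([C@H]2C[C@@H](n3cc(COc4ccc5oc(=O)ccc5c4)nn3)[C@@H](CO)O2)c(=O)[nH]c1=O` differs from compound 1 by a group of 11 heavy atoms (9 carbon, 2 oxygen; one six-membered aromatic ring of carbon only, one six-membered aromatic ring with 1 hetero atom) in place of a group of 10 heavy atoms (6 carbon, 1 nitrogen, 2 oxygen, 1 sulfur; one six-membered aromatic ring of carbon only), on an oxygen on a saturated carbon. Going by the values given here, no measured pair shows this change, so the expectation rests on compound 1 alone and on the fact that the two other measured compounds sit far above it in this assay. A large rise is expected, with the step from compound 1 to compound 4 estimated at a 100-fold higher number from compound 1 to compound 4 (2.01 log units; beyond the scatter). Compound 4 is therefore estimated at 6000 nM, expected to fall between 600 nM and 60000 nM.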

Compound 4, inhibition constant: 57.8 nM
Beside the measured number, compound 4's estimate is 100-fold (2.02 log units) above it; the measured number lies below the stated range.
By their numbers in this assay, from the lowest: compounds 4 and 1 (each within the scatter of the next); then compounds 3 and 2 (each within the scatter of the next).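

In this assay, exchanging the 4-sulfamoylphenyl on this oxygen for the bicyclic group gives a 1.0-fold lower number from compound 1 to compound 4 (0.01 log units; within the scatter) and so leaves the number unchanged within the scatter. Going by these compounds alone, this pair shows that a group with no sulfur, no nitrogen and no hydrogen-bond donors can stand here without a loss, which the earlier compounds, all carrying a sulfamoyl group, could not show. No measurement bears on why the two groups read alike. Still open, as far as these compounds go, is whether an unsubstituted phenyl or a phenyl bearing a carboxylic acid would hold this level on the same oxygen.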